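The source may report more compounds than this note shows. Statements on the series, on what has been measured and on what is new or still open speak of the compounds shown alone.

Compound 2 `COC(=O)/C=C/c1cccc(N(Cc2ccc(-c3ccc(C(C)(C)C)cc3)cc2)C(=O)C2CCCCC2)c1` gives 132 nM in an assay on isolated protein with Bile acid receptor (Homo sapiens) as the target (on this read-out lower numbers stand for an effect already at smaller amounts and higher numbers for an effect only at larger amounts of compound), and holds the lowest of the two numbers obtained in the series. Compound 1 `CCOc1cccc(-c2ccc(CN(C(=O)C(C)C)c3cccc(/C=C/C(=O)OC)c3)cc2)c1` gives 173 nM in this assay, and the gap between compound 1 and compound 2 falls within the scatter, so no order can be read from it. Compound 3 `COC(=O)/C=C/c1cccc(N(Cc2ccc(/C=C/C(=O)OC(C)(C)C)cc2OC(=O)c2ccccc2)C(=O)C2CCCCC2)c1` returns only a limit of the assay in this assay, > 1000 nM, and not a number; this is the limit of > 1000 nM in this assay, at which 1 of the 3 values shown sits.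

Compound 4 `COC(=O)/C=C/c1cccc(N(Cc2ccc(/C=C/c3c(Cl)cccc3Cl)cc2)C(=O)C2CCCCC2)c1` differs from compound 2 by 2-(2,6-dichlorophenyl)ethenyl in place of 4-(tert-butyl)phenyl on an aromatic carbon. The group that enters is carried on an aromatic carbon, para to a large group, as was the group that leaves. Going by the values given here, no measured pair shares this change, so the size of the step cannot be taken from a measured step. Compound 4 is expected to sit somewhat weaker than compound 2, with a step of a 2.3-fold higher number from compound 2 to compound 4 (0.36 log units; beyond the scatter) in this assay that may reach beyond the scatter. The estimate for compound 4 in this assay is 300 nM, with a range from 100 nM to 1500 nM.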

Compound 4, half-maximal effective concentration: 150 nM
The estimate for compound 4 lay 2.0-fold (0.30 log units) above the measured number, within the range that was stated.
By their numbers in this assay, from the lowest: compounds 2, 4 and 1 (each within the scatter of the next). At a limit, above all of these: compound 3.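

In this assay, 2-(2,6-dichlorophenyl)ethenyl in place of 4-(tert-butyl)phenyl gives a 1.1-fold higher number from compound 2 to compound 4 (0.06 log units; within the scatter). On this aromatic carbon, para to a large group, the two groups therefore cannot be told apart, although the entering group brings a double bond outside aromatic rings and two chlorine atoms. Nothing measured here accounts for this match between the two groups.

The double bond and the chlorine atoms enter together, so their separate contributions cannot be read, and the unsubstituted 2-phenylethenyl group would be needed to separate them. From the compounds shown here alone, it also remains open whether this position tolerates a carboxylic acid or an amine, since both groups compared here have no hydrogen-bond donors or acceptors and carry no net charge.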